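Replacing methoxy with nitro on a thiazolidinone series in Vero cells

The source may hold more compounds than are shown below. What is called first, only, known or untested is meant among the compounds shown, and "the series" means these compounds.

Measured so far:
compound 1, `COc1ccc(C2SCC(=O)N2CCN2CCCCC2)cc1`, 11%;
compound 2, `O=C1CSC(c2ccc([N+](=O)[O-])cc2)N1CCN1CCCCC1`, 15%;
compound 3, `COc1ccccc1C1SCC(=O)N1CCN1CCCCC1`, 17%.

The three measured compounds were tested in an ADME assay on Vero cells (Chlorocebus sabaeus) for cytotoxicity, read by neutral red uptake, tested at 1575 ug/mL; a higher number here means a weaker effect of the compound at the concentration tested, a lower number a stronger effect. In this assay compound 1 gives 11%, compound 2 gives 15% and compound 3 gives 17%. All three numbers lie close together, and the step of a number 4 percentage points higher from compound 1 to compound 2 (within the scatter) shows that the change nitro in place of methoxy on an aromatic carbon left the read-out essentially where it was.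

Compound 4, `O=C1CSC(c2ccccc2[N+](=O)[O-])N1CCN1CCCCC1`, has not yet been measured in this assay. It differs from compound 3 by nitro in place of methoxy on an aromatic carbon. Going by the values given here, this is the same kind of change as the one from compound 1 to compound 2, but not the same: in the earlier pair the nitro enters para to a large group, whereas in compound 4 it enters ortho to a large group. The difference between the two cores of compound 1 and compound 3 is not broken down here; the two have the same atoms, joined differently.

Because a number 4 percentage points higher from compound 1 to compound 2 (within the scatter) was within the scatter, the step from compound 3 to compound 4 is expected to be small as well, estimated as a number 3 percentage points higher from compound 3 to compound 4 (within the scatter). For compound 4 the estimated read-out in this assay is 20%, expected to lie between 8% and 33%.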

Compound 4, a percentage reported as activity, at one concentration (the size of the read-out at that concentration, not a potency): 24%
Compound 4: the middle estimate sits 4 percentage points below what was measured, within the range that was stated.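

In this assay, nitro in place of methoxy on an aromatic carbon gives a number 7 percentage points higher from compound 3 to compound 4 (within the scatter), and the same change on the earlier core gives a step that cannot be told apart from this one: the same change on two cores in this assay, a number 4 percentage points higher (within the scatter) from compound 1 to compound 2 and a number 7 percentage points higher (within the scatter) from compound 3 to compound 4, 3 percentage points apart, within the scatter of two such steps. Within these two pairs, then, the change carries from the core of compound 1 to the core of compound 3 without a detectable difference, even though the nitro in compound 4 stands ortho to a large group. Both steps lie within the scatter, however, and two pairs do not establish that the change has a real direction, nor that it would stay this small on any core beyond these two.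

The compounds shown carry only methoxy or nitro on the aromatic ring, so it remains open whether a chlorine, a hydroxyl or a carboxylic acid there would leave the read-out just as little moved. The chain joining the two nitrogen-bearing rings is also the same throughout, which leaves open what a longer chain or a primary amine in place of the terminal ring would do in this assay.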